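The source may hold more compounds than are shown below. What is called first, only, known or untested is meant among the compounds shown, and "the series" means these compounds.

Compound 2 `O=C(Nc1cccc2cccnc12)c1ncccn1` gives 330 nM in a functional assay on MIA PaCa-2 cells (Homo sapiens) for inhibition, read by MTT assay, with a stated time of 72 h (on this read-out lower numbers stand for stronger inhibition and higher numbers for weaker inhibition), the lowest of the two numbers shown; compound 1 `O=C(Nc1cccc2cccnc12)c1cccnn1` gives 8500 nM, and the step of a 26-fold lower number from compound 1 to compound 2 (1.41 log units; beyond the scatter) is a swap of one small heteroaryl ring for another on the carbonyl carbon. Compound 3 `Cc1ccc2cccc(NC(=O)c3ncccn3)c2n1` reaches only a limit of this assay, > 10000 nM. The step of an at least 30-fold higher number from compound 2 to compound 3 (1.48 log units; beyond the scatter) shows that even a methyl on the shared core can cost a great deal. Compound 4 `NCCOc1cc(NC(=O)c2ncccn2)c2ncccc2c1` differs from compound 2 by 2-aminoethoxy in place of hydrogen on an aromatic carbon. Among the measured compounds shown here, only the step to compound 3 bears on this change, and it was large, though the new group is larger and sits elsewhere. For compound 4 a loss is expected, of uncertain size, namely a 6.1-fold higher number from compound 2 to compound 4 (0.78 log units; beyond the scatter). Compound 4 is estimated at 2000 nM, between 300 nM and 10000 nM.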

Compound 4, half-maximal inhibitory concentration: > 10000 nM
Compound 4 gave a limit, no number; the forecaster's own chance of this, stated with the estimate: 25%; at least 5.0-fold (0.69 log units) between middle value and limit.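

In this assay, the step of an at least 30-fold higher number from compound 2 to compound 4 (1.48 log units; beyond the scatter) shows that a large loss also comes with a change at this aromatic carbon, not only with the methyl of compound 3. Compound 4 gives a limit, > 10000 nM, so this loss has a lower bound but no measured size. Compound 3 and compound 4 cannot be ranked against each other because both sit at the same limit: the limit of > 10000 nM in this assay, at which 2 of the 4 values shown sit.

Going by these compounds, whether a small methoxy or a hydroxyl at this position would fare better remains open. So does the question of whether the amine or the rest of the 2-aminoethoxy chain matters more.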